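A few compounds are considered here, and "the series" means these few. Any claim that something is new, unique, unknown or untested is made for them only; others in the source may bear on it.

Working notes on the series. Among the measured compounds shown here, in a functional assay on PC-12 cells (Rattus norvegicus) for cytotoxicity, read by MTT assay, with stated times of 2 h and 24 h, tested at 5 uM (on this read-out higher numbers stand for a stronger effect at the one concentration tested and lower numbers for a weaker effect), compound 1 `Oc1cc(C(F)(F)F)ccc1-c1nc(-c2ccccc2O)n(-c2ccc(F)cc2)n1` gives 86.7%, the lowest of the three numbers so far, though the other two sit within the scatter of it. Compound 2 `Oc1cc(C(F)(F)F)ccc1-c1nc(-c2ccccc2O)n(-c2ccc(I)cc2)n1` gives 94.4% and compound 3 `Cc1ccc(-n2nc(-c3ccc(C(F)(F)F)cc3O)nc2-c2ccccc2O)c(C)c1` gives 93.3%. The unmeasured compound 4 `Oc1cc(C(F)(F)F)ccc1-c1nc(-c2ccccc2O)n(-c2ccc(F)cc2F)n1` differs from compound 1 by fluoro in place of hydrogen on an aromatic carbon, which read one bond further out is 4-fluorophenyl to 2,4-difluorophenyl. The measured steps that bear on it all alter the same aryl group on the aromatic nitrogen: a number 7.7 percentage points higher from compound 1 to compound 2 (within the scatter), a number 6.6 percentage points higher from compound 1 to compound 3 (within the scatter) and a number 1.1 percentage points lower from compound 2 to compound 3 (within the scatter). None of these moved the read-out beyond the scatter, and the change to compound 4 is smaller than any of them. In this assay a step of no more than the scatter is therefore expected, with no direction to assign; the expected step from compound 1 is a number 2.3 percentage points higher from compound 1 to compound 4 (within the scatter). Compound 4 is accordingly estimated at 89%, in the range 78% to 97%. This expectation rests on compound 1 giving 86.7% and on the comparable steps staying within the scatter.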

Compound 4, a percentage reported as activity, at one concentration (the size of the read-out at that concentration, not a potency): 83.5%
For compound 4 the middle estimate is 5.5 percentage points above the measured one; measured number inside the range.
By their numbers in this assay, from the lowest: compounds 4, 1, 3 and 2 (each within the scatter of the next, the first and the last beyond it).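

In this assay, fluoro in place of hydrogen on an aromatic carbon, ortho to a large group, gives the series its first change at this position, and the step is a number 3.2 percentage points lower from compound 1 to compound 4 (within the scatter). Against the other aryl groups on the aromatic nitrogen, the comparison gives a number 9.8 percentage points lower from compound 3 to compound 4 (within the scatter) and a number 10.9 percentage points lower from compound 2 to compound 4 (beyond the scatter), the latter being the first modest gap in the series beyond the scatter. Nothing available gives a reason for any of these steps.

Still open, as far as these compounds go, is how this same aromatic carbon responds to a group other than fluoro, such as an amine, a methoxy group or a carboxylic acid. With a read-out at one concentration, the potency of these compounds also remains open.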